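From 2-methylphenyl to 2,4-dimethylphenyl in compound 4

A few compounds are considered here, and "the series" means these few. Any claim that something is new, unique, unknown or untested is made for them only; others in the source may bear on it.

Of the compounds shown here, three sharing one core have been measured in a functional assay on MCF7 cells (Homo sapiens) for antiproliferative activity, read by MTT assay, with a stated time of 72 h; on this read-out higher numbers stand for weaker inhibition and lower numbers for stronger inhibition. Compound 1 `Nc1nc(N)c2cc(CSC(=S)N3CCN(c4ccc(O)cc4)CC3)ccc2n1` gives 5090 nM, compound 2 `Cc1ccc(N2CCN(C(=S)SCc3ccc4nc(N)nc(N)c4c3)CC2)cc1` gives 2480 nM, and compound 3 `Cc1ccccc1N1CCN(C(=S)SCc2ccc3nc(N)nc(N)c3c2)CC1` gives 4230 nM. Compound 3 thus stands within the scatter of both other compounds, although those two are separated by slightly more than the scatter.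

The unmeasured compound 4 `Cc1ccc(N2CCN(C(=S)SCc3ccc4nc(N)nc(N)c4c3)CC2)c(C)c1` carries methyl in place of hydrogen on an aromatic carbon of compound 3, meta to a methyl group and para to a large group: methyl in place of hydrogen on an aromatic carbon. For the measured compounds named here, no measured step makes this exact addition, so the evidence is indirect. The exchange of hydroxy for methyl gave a 2.1-fold lower number from compound 1 to compound 2 (0.31 log units; beyond the scatter), a modest step. Moving to the 2-methylphenyl group gave a 1.7-fold higher number from compound 2 to compound 3 (0.23 log units; within the scatter), and a 1.2-fold lower number from compound 1 to compound 3 (0.08 log units; within the scatter) is also small. Compound 4 holds the 2-methylphenyl pattern of compound 3 along with a methyl at the place it occupies in compound 2, and all these steps are small. The expected change in this assay is a 1.4-fold lower number from compound 3 to compound 4 (0.15 log units; within the scatter), a small move towards a lower number that is not expected to pass the scatter. For compound 4 the estimate is 3000 nM, with an expected range of 1500 nM to 6000 nM.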

Compound 4, half-maximal inhibitory concentration: 3120 nM
The estimate for compound 4 lay 1.0-fold (0.02 log units) below the measured number; the measured number falls inside the stated range.
By their numbers in this assay, from the lowest: compounds 2, 4, 3 and 1 (each within the scatter of the next, the first and the last beyond it).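

In this assay, for the compounds shown here, methyl in place of hydrogen on the aromatic carbon para to a large group gives a 1.4-fold lower number from compound 3 to compound 4 (0.13 log units; within the scatter), the first direct reading of this addition, and it stays within the scatter. Read from the other side, the 2,4-dimethylphenyl group gives a 1.3-fold higher number from compound 2 to compound 4 (0.10 log units; within the scatter), so the two methyl groups together are not separated beyond the scatter from either single-methyl compound. Against the 4-hydroxyphenyl group, the 2,4-dimethylphenyl group gives a 1.6-fold lower number from compound 1 to compound 4 (0.21 log units; within the scatter), also within the scatter, whereas a 2.1-fold lower number from compound 1 to compound 2 (0.31 log units; beyond the scatter) lies just beyond it, so of these two exchanges only the one to the 4-methylphenyl group passes the scatter. No independent measurement bears on why these steps are so small.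

The compounds shown leave open whether a group other than methyl on this aromatic carbon, such as chlorine, a methoxy group, an amine or a carboxylic acid, would produce a step beyond the scatter. They also leave open whether a longer chain such as ethyl at this place would stay as close to compound 3 as the methyl group of compound 4 does.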